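Swapping Chloro for Amino on a Scaffold Without a Reading

The source may hold more compounds than are shown below. What is called first, only, known or untested is meant among the compounds shown, and "the series" means these compounds.

Compound 1 `Fc1cccc(-c2nc(Nc3cccc(Cl)c3)c3cc(F)ccc3n2)c1` was tested in a functional assay on U-937 cells (Homo sapiens) for cytotoxicity, read by MTT assay, with a stated time of 48 h; a higher number here means a weaker inhibitor, a lower number a stronger inhibitor. In this assay compound 1 gives > 50000 nM, which is a limit of the assay rather than a measured number. Compound 2 `Fc1cccc(-c2nc(Nc3ccc(Br)cc3)c3cc(F)ccc3n2)c1` differs from compound 1 only in the 4-bromophenyl in place of 3-chlorophenyl on a nitrogen on an aromatic ring. In this assay compound 2 gives > 50000 nM, again a limit and not a number. The step that the two limits leave unreadable from compound 1 to compound 2 therefore cannot be sized. Both measured values sit at the limit of > 50000 nM in this assay, at which 2 of the 2 values shown sit, so the shared core has so far shown no readable cytotoxicity at all.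

Compound 3 `Nc1cccc(Nc2nc(-c3cccc(F)c3)nc3ccc(F)cc23)c1` has not yet been measured. It differs from compound 1 by amino in place of chloro on an aromatic carbon. Going by the values given here, no measured step involves an amino group, so the only guidance is that the two compounds already examined reach the same limit. The step of a number no higher from compound 1 to compound 3 (the limit leaves the size open) is expected to be small, and compound 3 is expected to stay close to that limit. Compound 3 is therefore estimated at 50000 nM, with a range from 10000 nM to 100000 nM, and a real chance that only a limit is reported again.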

Compound 3, half-maximal inhibitory concentration: > 50000 nM
Compound 3: a limit, no number (the forecaster's own chance of this, stated with the estimate: 70%); the middle value lies on the limit itself.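

In this assay compound 3 gives > 50000 nM as a limit of the assay and not a number. Compound 1 and compound 2 also stop at a limit, so neither step to compound 3 can be read. Still open, going by these compounds, is whether any change to the shared core gives a readable cytotoxicity value.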